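Methyl on the benzyloxy ring across two amide cores

A few compounds are considered here, and "the series" means these few. Any claim that something is new, unique, unknown or untested is made for them only; others in the source may bear on it.

Measured in an assay on isolated protein for agonist activity at Bile acid receptor (Homo sapiens), read by TR-FRET, with a stated time of 3 h, in the absence of a further agent; a higher number here means that more compound is needed for the effect, a lower number that less compound is needed:
Compound 1, `O=C(O)c1cccc(NC(=O)c2ccc(OCc3ccccc3)cc2)c1`, gives 135 nM.
Compound 2, `Cc1cccc(COc2ccc(C(=O)Nc3cccc(C(=O)O)c3)cc2)c1`, gives 259 nM.
Compound 3, `O=C(O)c1cccc(NC(=O)c2cccc(OCc3ccccc3)c2)c1`, gives 1160 nM.

Compound 1 and compound 2 share one core and differ only by methyl in place of hydrogen on an aromatic carbon. That change made the step of a 1.9-fold higher number from compound 1 to compound 2 (0.28 log units; within the scatter). Compound 3 has the same atoms as compound 1, joined differently; the difference between the two cores is not broken down here. What the numbers show is that compound 3 stands highest of the three, beyond the scatter from compound 2 and further still from compound 1.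

Compound 4, `Cc1cccc(COc2cccc(C(=O)Nc3cccc(C(=O)O)c3)c2)c1`, is not yet measured. It stands to compound 3 as compound 2 stands to compound 1: the change is methyl in place of hydrogen on an aromatic carbon. The place of the change reads the same in both pairs, so this is the same change, now made on the core of compound 3. Among these compounds the change occurs twice and has one measured outcome so far. Because the step of a 1.9-fold higher number from compound 1 to compound 2 (0.28 log units; within the scatter) stayed within the scatter, the expected step for compound 4 is a 1.6-fold higher number from compound 3 to compound 4 (0.21 log units; within the scatter). Compound 4 is estimated at 1900 nM, with a range from 800 nM to 5000 nM. Whether the second core answers the methyl as the first did is what the coming measurement in this assay will show.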

Compound 4, half-maximal effective concentration: 1860 nM
For compound 4 the middle estimate is 1.0-fold (0.01 log units) above the measured one, and the stated range covers the measured number.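

In this assay, the methyl that turns benzyl into 3-methylbenzyl gives a 1.6-fold higher number from compound 3 to compound 4 (0.21 log units; within the scatter), a small step on the core of compound 3, as it was on the core of compound 1. Set side by side, the two steps do not differ, so on these two cores the change carries over with no measurable dependence on the core: the same change on two cores in this assay, a 1.9-fold higher number (0.28 log units; within the scatter) from compound 1 to compound 2 and a 1.6-fold higher number (0.21 log units; within the scatter) from compound 3 to compound 4, 1.2-fold (0.08 log units) apart, within the scatter of two such steps This does not show that the methyl has any real effect, since each step lies within the scatter, and it does not show that the result would hold on a third core, as the evidence is one group at one place on only two cores; nor does it explain the gap between the two cores themselves, which remains beyond the scatter and is untouched by the methyl.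

Still open, from the compounds shown here alone, is whether a larger or different group at the same place on the ring, such as an ethyl, a methoxy or an amine, would also give matching steps on both cores. Also open, going by these compounds, is what follows when the carboxylic acid shared by all four compounds gives way to a nitrile or a primary amide.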